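The source may report more compounds than this note shows. Statements on the series, on what has been measured and on what is new or still open speak of the compounds shown alone.

Compound 1 `OC[C@H]1O[C@@H](n2cc(F)c3c(-c4ccsc4)ncnc32)[C@H](O)[C@@H]1O`: 620 nM
Compound 2 `OC[C@H]1O[C@@H](n2cc(F)c3c(-c4ccc[nH]4)ncnc32)[C@H](O)[C@@H]1O`: 2990 nM
Compound 3 `OC[C@H]1O[C@@H](n2cc(F)c3c(-c4cc[nH]c4)ncnc32)[C@H](O)[C@@H]1O`: 2020 nM

In an ADME assay on BJ cells (Homo sapiens) for cytotoxicity, read by MTT assay, with a stated time of 72 h (a higher number here means that more compound is tolerated, a lower number that less compound is tolerated), compound 1 has the lowest number of the three. Compound 4 `OC[C@H]1O[C@@H](n2cc(Cl)c3c(-c4ccsc4)ncnc32)[C@H](O)[C@@H]1O` keeps its thiophen-3-yl group but carries chloro in place of fluoro on an aromatic carbon. Among the compounds with values here, no measured step makes this change. The nearest evidence comes from replacing thiophen-3-yl with a pyrrolyl group, which gave modest steps: a 4.8-fold higher number from compound 1 to compound 2 (0.68 log units; beyond the scatter) and a 3.3-fold higher number from compound 1 to compound 3 (0.51 log units; beyond the scatter). Exchanging the two pyrrolyl groups gave a 1.5-fold lower number from compound 2 to compound 3 (0.17 log units; within the scatter), within the scatter. These steps indicate only how far a single change has moved this series, not the direction for chloro, so no step beyond the scatter is expected. The expected step is a 1.1-fold higher number from compound 1 to compound 4 (0.05 log units; within the scatter). For compound 4 the estimate is 700 nM, with an expected range from 200 nM to 2400 nM.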

Compound 4, half-maximal cytotoxic concentration: 1720 nM
Beside the measured number, compound 4's estimate is 2.5-fold (0.39 log units) below it, within the range that was stated.
By their numbers in this assay, from the lowest: compound 1; then compounds 4, 3 and 2 (each within the scatter of the next).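

Chloro in place of fluoro raises the number in this assay (a 2.8-fold higher number from compound 1 to compound 4 (0.44 log units; beyond the scatter)), so more compound is tolerated. Until now, only changes to the thiophen-3-yl group had been seen to move this number; this result shows that a single-atom exchange on the aromatic carbon two ring bonds from the ring nitrogen can also do so. Nothing measured here explains the step. Still open, on these data alone, is whether bromo, methyl or a nitrile on this carbon would shift the number, and whether chloro would act alike with 1H-pyrrol-2-yl in place of thiophen-3-yl.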